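Replacing 4-nitrophenyl with 2-bromophenyl: an expected step

The source may report more compounds than this note shows. Statements on the series, on what has been measured and on what is new or still open speak of the compounds shown alone.

Compound 1 `O=c1ccoc2cc(OCc3cn(Cc4cccc(F)c4)nn3)ccc12` gives 7550 nM
Compound 2 `O=c1ccoc2cc(OCc3cn(Cc4ccc([N+](=O)[O-])cc4)nn3)ccc12` gives 25700 nM

Both values come from a functional assay on HeLa cells (Homo sapiens) for cytotoxicity, read by MTT assay, with a stated time of 48 h (on this read-out higher numbers stand for weaker inhibition and lower numbers for stronger inhibition), and compound 2 holds the higher of the two numbers, which makes it the weaker of this pair. Compound 3 `O=c1ccoc2cc(OCc3cn(Cc4ccccc4Br)nn3)ccc12` has not yet been measured. It carries 2-bromophenyl in place of 4-nitrophenyl on a saturated chain carbon bound to an aromatic nitrogen. Among the measured compounds shown here, the one measured step at that place is a 3.4-fold higher number from compound 1 to compound 2 (0.53 log units; beyond the scatter) and it is modest but beyond the scatter. That step ends on the same 4-nitrophenyl that compound 3 lacks. For the measured compounds named here, no measured compound carries 2-bromophenyl, so the evidence is thin. Going by the values given here, the only compound without 4-nitrophenyl is compound 1 at 7550 nM and this suggests a move back toward that level. The estimated change is a 2.3-fold lower number from compound 2 to compound 3 (0.37 log units; beyond the scatter) and so a modest one toward a lower number. Compound 3 is expected at 11000 nM within an estimated range from 4000 nM to 30000 nM overall.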

Compound 3, half-maximal inhibitory concentration: 14500 nM
Estimate against measurement, compound 3: 1.3-fold (0.12 log units) below; low and high end bracket the measured number.
By their numbers in this assay, from the lowest: compounds 1, 3 and 2 (each within the scatter of the next, the first and the last beyond it).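

In this assay, 2-bromophenyl on a saturated chain carbon bound to an aromatic nitrogen cannot be told apart from either of the groups seen earlier at this position: replacing 4-nitrophenyl with it gives a 1.8-fold lower number from compound 2 to compound 3 (0.25 log units; within the scatter), and replacing 3-fluorophenyl with it gives a 1.9-fold higher number from compound 1 to compound 3 (0.28 log units; within the scatter). Among the compounds shown here, the only step among the three compounds that lies beyond the scatter is still a 3.4-fold higher number from compound 1 to compound 2 (0.53 log units; beyond the scatter), so that gap stands without a matching separation of compound 3 from either compound 1 or compound 2, and the three compounds do not form a clean series. Nothing in the available data accounts for these numbers.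

From the compounds shown here alone, all three compounds carry a substituted phenyl ring at this position, so it remains open whether an amine, a carboxylic acid or a longer chain would be accommodated there in the same range. It is also open whether the number for compound 3 depends on the bromine itself or on where it sits, since 3-bromophenyl and 4-bromophenyl are absent from the compounds shown.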